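Ring substituent removal in a bicyclic amine series

A few compounds are considered here, and "the series" means these few. Any claim that something is new, unique, unknown or untested is made for them only; others in the source may bear on it.

Compound 1 `CSc1ccc(CN[C@@H]2C[C@H]3C[C@@H]([C@H]2C)C3(C)C)s1`: 25000 nM
Compound 2 `CCc1ccsc1CN[C@@H]1C[C@H]2C[C@@H]([C@H]1C)C2(C)C`: 25000 nM
Compound 3 `C[C@H]1[C@H](NCc2sccc2C2CC2)C[C@H]2C[C@@H]1C2(C)C`: 25000 nM

In an ADME assay on MDCK cells (Canis lupus familiaris) for cytotoxicity, read by microscopy, with a stated time of 48 h (a lower number here means that less compound is tolerated, a higher number that more compound is tolerated), compound 1 gives 25000 nM, level at the digits shown with compound 2 and compound 3. For the measured compounds named here, the single measured step, no change at the digits printed from compound 2 to compound 3 (within the scatter), exchanged one group for another on an aromatic carbon and left the read-out unmoved.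

Compound 4 `C[C@H]1[C@H](NCc2cccs2)C[C@H]2C[C@@H]1C2(C)C` differs from compound 1 by hydrogen in place of methylsulfanyl on an aromatic carbon. Going by the values given here, no measured step removes a ring group outright, so the evidence is indirect: the one step available shows no change, and all three measured values sit at one level. The expected step is therefore no change at the digits printed from compound 1 to compound 4 (within the scatter), nothing beyond the scatter in this assay. Compound 4 is estimated at 25000 nM, with a range from 12500 nM to 50000 nM.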

Compound 4, minimum cytotoxic concentration: 25000 nM
Compound 4: the middle estimate sits on the measured number at the digits printed; measured number inside the range.
By their numbers in this assay, from the lowest: compounds 1, 2, 3 and 4 (each within the scatter of the next).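

Hydrogen on this aromatic carbon, next to the ring sulfur, shows that the ring without a substituent reads the same in this assay as the methylsulfanyl compound (no change at the digits printed from compound 1 to compound 4 (within the scatter)). The ethyl and cyclopropyl compounds also read level with it (no change at the digits printed from compound 2 to compound 4 (within the scatter)) (no change at the digits printed from compound 3 to compound 4 (within the scatter)), so removing a ring group outright leaves the read-out as unmoved as exchanging one did. No measurement shown accounts for this flat result.

The compounds shown leave open whether a carboxylic acid or an amine on this aromatic carbon would shift the read-out.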